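Ethynyl for thiophen-2-yl on two related nucleoside cores

A few compounds are considered here, and "the series" means these few. Any claim that something is new, unique, unknown or untested is made for them only; others in the source may bear on it.

Compound 1 `Cc1nc(N)c2c(-c3cccs3)cn([C@@H]3O[C@H](CO)[C@@H](O)[C@H]3O)c2n1` and compound 2 `COc1nc(N)nc2c1c(-c1cccs1)cn2[C@@H]1O[C@H](CO)[C@@H](O)[C@H]1O` share a core whose difference is not broken down here. In a functional assay on HeLa S3 cells (Homo sapiens) for antiproliferative activity, read by XTT assay, with a stated time of 72 h (a lower number here means a stronger inhibitor, a higher number a weaker inhibitor), compound 1 gives only a limit, > 20000 nM. Compound 2 likewise gives only a limit in this assay, > 20000 nM. Compound 3 `C#Cc1cn([C@@H]2O[C@H](CO)[C@@H](O)[C@H]2O)c2nc(C)nc(N)c12` differs from compound 1 by ethynyl in place of thiophen-2-yl on an aromatic carbon, and in this assay compound 3 gives only a limit, > 20000 nM. The step that the two limits leave unreadable from compound 1 to compound 3 therefore has no readable size, because of the limit of > 20000 nM in this assay, at which 3 of the 3 values shown sit. Compound 4 `C#Cc1cn([C@@H]2O[C@H](CO)[C@@H](O)[C@H]2O)c2nc(N)nc(OC)c12` carries the same change from compound 2, (ethynyl in place of thiophen-2-yl on an aromatic carbon), at a place described in identical words. The step that the limit leaves unreadable from compound 2 to compound 4 is expected to stay unreadable because compound 2 already sits at the limit > 20000 nM. Compound 4 is estimated at 30000 nM in this assay, most probably reported once more as a limit.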

Compound 4, half-maximal inhibitory concentration: > 20000 nM
Compound 4: no number, only a limit (the forecaster's own chance of this, stated with the estimate: 85%); the middle value lies beyond the limit too.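

No size can be read for the step between compound 2 and compound 4, as both give only limits in this assay: the limit of > 20000 nM in this assay, at which 4 of the 4 values shown sit.

The compounds shown leave open how ethynyl and thiophen-2-yl compare on either core.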